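Hydrazide of a nitrobenzimidazole: furan hydrazone in place of isopropylidene

A few compounds are considered here, and "the series" means these few. Any claim that something is new, unique, unknown or untested is made for them only; others in the source may bear on it.

Compound 1 `Cc1nc2cc(C(=O)NN)c([N+](=O)[O-])cc2[nH]1`: in a functional assay on A549 cells (Homo sapiens) for cytotoxicity, read by resazurin assay, with a stated time of 72 h (a lower number here means a stronger inhibitor, a higher number a weaker inhibitor), compound 1 gives > 100000 nM, which is a limit of the assay.
Compound 2 `CC(C)=NNC(=O)c1ccc2[nH]c(C)nc2c1`: in this assay compound 2 gives > 100000 nM, a limit of the assay.
Compound 3 `CC(C)=NNC(=O)c1cc2nc(C)[nH]c2cc1[N+](=O)[O-]`: in this assay compound 3 gives > 100000 nM, again a limit of the assay.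

Compound 3 therefore stands at a limit, and so do the two compounds around it; none of the three gives a number. The step that the two limits leave unreadable from compound 1 to compound 3 and the step that the two limits leave unreadable from compound 2 to compound 3 are both unreadable for the same reason, since the limit of > 100000 nM in this assay, at which 3 of the 3 values shown sit, describes every value shown. Compound 4 `Cc1nc2cc(C(=O)N/N=C\c3ccco3)c([N+](=O)[O-])cc2[nH]1` differs from compound 3 in one place: a group of 7 heavy atoms (5 carbon, 1 nitrogen, 1 oxygen; one five-membered aromatic ring with 1 hetero atom) in place of a group of 4 heavy atoms (3 carbon, 1 nitrogen; no ring), on an amide-type nitrogen.

Which measured steps bear on this change? Going by the values given here, only the step from compound 1 to compound 3 touches the same amide-type nitrogen, and its size cannot be read. Nothing shown, then, allows a direction or a size to be predicted for the step in this assay. Since every compound is at the limit, the most likely outcome is that compound 4 stays at the limit as well, with the remaining chance that the new five-membered aromatic ring brings a readable number. The expected step of a number no higher from compound 3 to compound 4 (the limit leaves the size open) is accordingly set close to none. Compound 4 is estimated at 100000 nM, within 20000 nM to 300000 nM.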

Compound 4, half-maximal inhibitory concentration: > 100000 nM
Compound 4: only a limit was reported (the forecaster's own chance of this, stated with the estimate: 70%); the middle value sits exactly at the limit.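

In this assay compound 4 gives > 100000 nM, which is a limit of the assay and not a number. The steps to compound 4 from compound 1 and from compound 3 therefore cannot be read, and one limit covers the whole set: the limit of > 100000 nM in this assay, at which 4 of the 4 values shown sit. The compounds shown leave open whether any change on the amide-type nitrogen gives a readable number in this assay.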